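Replacing a formyl group by cyanosulfanyl on the shared core

The source may hold more compounds than are shown below. What is called first, only, known or untested is meant among the compounds shown, and "the series" means these compounds.

Measured so far:
compound 1 `O=Cc1c(-c2ccc(Br)cc2)nc2sc(Cc3ccc(Cl)cc3)nn12`: 4600 nM
compound 2 `O=Cc1c(-c2ccccc2)nc2sc(Cc3ccc(Cl)cc3)nn12`: 20000 nM

Both were tested in a functional assay on L1210 cells (Mus musculus) for cytotoxicity, with a stated time of 48 h; a higher number here means a weaker inhibitor, a lower number a stronger inhibitor. Among the measured compounds shown here, compound 2 has the highest of the two numbers; the only recorded step, a 4.3-fold higher number from compound 1 to compound 2 (0.64 log units; beyond the scatter), involves hydrogen in place of bromo and is modest. Compound 3 `N#CSc1c(-c2ccccc2)nc2sc(Cc3ccc(Cl)cc3)nn12` differs from compound 2 by cyanosulfanyl in place of formyl on an aromatic carbon. For the measured compounds named here, no measured step involves this kind of change, so the data give no direction for it. Compound 3 is therefore expected to show a step of no change at the digits printed from compound 2 to compound 3 (within the scatter), nothing beyond the scatter. Compound 3 is estimated at 20000 nM in this assay, with a range from 5000 nM to 60000 nM.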

Compound 3, half-maximal inhibitory concentration: 24000 nM
Beside the measured number, compound 3's estimate is 1.2-fold (0.08 log units) below it; the measured number falls inside the stated range.
By their numbers in this assay, from the lowest: compound 1; then compounds 2 and 3 (each within the scatter of the next).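

In this assay replacing formyl by cyanosulfanyl on this aromatic carbon gives a 1.2-fold higher number from compound 2 to compound 3 (0.08 log units; within the scatter) and so, with the phenyl group present, the two groups cannot be told apart by this read-out. Among the compounds shown here, the earlier step concerned only bromo and hydrogen, so this is the first view of this position, and it shows that a larger group with a triple bond can stand here without a change beyond the scatter. Nothing available explains this result. Going by these compounds, whether the swap gives the same outcome with the bromo of compound 1 present remains open. So does how an amine or a carboxylic acid would read on this carbon.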